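This account rests on a few compounds, and the source may have more. Where it says the series, first, only, none or still open, it means among the compounds named here.

The measured compounds and their values:

compound 1 `CC(C)(C)c1cc(NC(=O)[C@@H]2CCCCN2C(=O)c2ccccc2)no1` in a physicochemical assay for solubility, read by HPLC, at pH 6.8 (on this read-out higher numbers stand for higher solubility and lower numbers for lower solubility), gives 0.9 ug/mL
compound 2 `CC(C)(C)c1cc(NC(=O)[C@@H]2CCCCN2C(=O)C2CCCCC2)no1` in this assay gives 6.4 ug/mL

Of these two numbers, compound 2 holds the higher one. Among the compounds with values here, its only neighbour is compound 1, and the single measured step, a 7.1-fold higher number from compound 1 to compound 2 (0.85 log units; beyond the scatter), lies beyond the scatter. Compound 3 `CC(C)(C)c1cc(NC(=O)[C@@H]2CCCCN2C(=O)C2CCS(=O)(=O)CC2)no1` is the compound still to be measured. It differs from compound 2 in one place: 1,1-dioxothian-4-yl in place of cyclohexyl on a carbonyl carbon.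

Within the data shown here, no measured step involves the group that enters here. Among the measured compounds shown here, the one step on record, a 7.1-fold higher number from compound 1 to compound 2 (0.85 log units; beyond the scatter), concerns the exchange of phenyl for cyclohexyl at the same carbonyl carbon, and it shows only that a change at this position can shift this assay by a modest amount well beyond the scatter. The direction for compound 3 therefore rests on the counted difference alone, in which a ring containing sulfur and oxygen, with two hydrogen-bond acceptors, replaces a ring of carbon only.

On that basis compound 3 is expected to show a higher number than compound 2, the expected step being a 4.7-fold higher number from compound 2 to compound 3 (0.67 log units; beyond the scatter). The estimate for compound 3 is 30 ug/mL, with a range from 10 ug/mL to 100 ug/mL.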

Compound 3, solubility: 67 ug/mL
Estimate against measurement, compound 3: 2.2-fold (0.35 log units) below; low and high end bracket the measured number.
By their numbers in this assay, from the lowest: compound 1; then compound 2; then compound 3.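

Within the data shown here, at the carbonyl carbon whose other neighbour is the amide-type nitrogen in a ring, 1,1-dioxothian-4-yl in place of cyclohexyl gives a 10-fold higher number from compound 2 to compound 3 (1.02 log units; beyond the scatter) in this assay, a large step where the only earlier step at this place was modest. Set against phenyl, the same group gives a 74-fold higher number from compound 1 to compound 3 (1.87 log units; beyond the scatter), so the three groups now run in the order phenyl, cyclohexyl, 1,1-dioxothian-4-yl, with each gap beyond the scatter. The earlier pair showed only an exchange between two rings of carbon alone, whereas compound 3 shows that a six-membered ring with a hetero atom and hydrogen-bond acceptors, kept at this same place, reaches a higher number than either of them.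

The compounds shown leave open whether a simple ether oxygen in the ring, an amine or a carboxylic acid at this carbonyl carbon would go as far, and whether the step would hold with any other part of the shared core changed. Nothing available accounts for the size of this step.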